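The source may report more compounds than this note shows. Statements on the series, on what has been measured and on what is new or still open speak of the compounds shown alone.

Of the compounds shown here, three that share one core have been measured in a functional assay on K562 cells (Homo sapiens) for inhibition; a higher number here means a weaker inhibitor, a lower number a stronger inhibitor. Compound 1 (`CCOc1ccc(Br)cc1-c1cc(Nc2ccc(C#N)cc2)nc(N)n1`) gives 70 nM, compound 2 (`CCOc1ccc(Br)cc1-c1cc(Nc2cccc(C#N)c2)nc(N)n1`) gives 350 nM, and compound 3 (`CCOc1ccc(Br)cc1-c1cc(Nc2ccc(C(=O)NO)cc2)nc(N)n1`) gives 700 nM. Compound 3 and compound 2 lie within the usual scatter of each other, and both are clearly weaker than compound 1.

Compound 4 (`CCOc1ccc(Br)cc1-c1cc(Nc2ccccc2)nc(N)n1`) puts hydrogen in place of hydroxycarbamoyl on an aromatic carbon. Going by the values given here, two measured steps bear on this site. Swapping the group at the same place gave a 10-fold higher number from compound 1 to compound 3 (1.00 log units; beyond the scatter), and moving the nitrile gave a 5.0-fold higher number from compound 1 to compound 2 (0.70 log units; beyond the scatter). Among the compounds with values here, both are modest, so the ring substituent matters, but no measured compound has this ring without a substituent. The direction is therefore uncertain, and a slightly lower number in this assay is expected, with no change beyond the scatter. The estimated step is a 1.6-fold lower number from compound 3 to compound 4 (0.19 log units; within the scatter). For compound 4 the expected value is 450 nM, with an estimated range of 120 nM to 1800 nM.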

Compound 4, half-maximal inhibitory concentration: 260 nM
For compound 4 the middle estimate is 1.7-fold (0.24 log units) above the measured one; low and high end bracket the measured number.
By their numbers in this assay, from the lowest: compound 1; then compounds 4, 2 and 3 (each within the scatter of the next, the first and the last beyond it).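

Against the unsubstituted ring, now available as a baseline, hydroxycarbamoyl turns out to be a loss rather than a neutral group: putting hydrogen in its place gives a 2.7-fold lower number from compound 3 to compound 4 (0.43 log units; beyond the scatter) in this assay and so shows weaker inhibition with that group present. The nitrile depends on where it sits: hydrogen in its place gives a 3.7-fold higher number from compound 1 to compound 4 (0.57 log units; beyond the scatter) for the placement in compound 1, so only there does it beat hydrogen, while a 1.3-fold lower number from compound 2 to compound 4 (0.13 log units; within the scatter) for the placement in compound 2 leaves it indistinguishable from hydrogen. Nothing shown here explains why these groups differ.

Going by these compounds alone, only two groups have been compared with hydrogen, so it remains open how an amine, a carboxylic acid or a methoxy group would behave at this carbon. On these data alone, it is also open whether any group can give a lower number than the nitrile of compound 1.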